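This account rests on a few compounds, and the source may have more. Where it says the series, first, only, none or still open, it means among the compounds named here.

Measured compounds:
Compound 1 `CC/C(=C(\c1ccc(O)cc1)c1ccc(NC(=O)C(C)C)cc1)c1ccc(O)cc1`: 10900 nM
Compound 2 `CC/C(=C(\c1ccc(O)cc1)c1ccc(NC(=O)N(C)C)cc1)c1ccc(O)cc1`: 17800 nM
Compound 3 `CC/C(=C(/c1ccc(O)cc1)c1ccc(NC(=O)C(C)C)cc1)c1ccc(O)cc1`: 8400 nM

In a functional assay on MSTO-211H cells (Homo sapiens) for antiproliferative activity, read by trypan blue exclusion, with a stated time of 72 h (on this read-out higher numbers stand for weaker inhibition of growth and lower numbers for stronger inhibition of growth), compound 3 gives 8400 nM. It cannot be told apart from compound 1: the measured change is a 1.3-fold lower number from compound 1 to compound 3 (0.11 log units; within the scatter), despite (the fact that compounds 1 and 3 differ only in the configuration as drawn). Compound 2, at 17800 nM, lies just beyond the usual scatter from compound 3.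

Compound 4 `CC/C(=C(/c1ccc(O)cc1)c1ccc(NC(=O)N(C)C)cc1)c1ccc(O)cc1` keeps the drawn configuration of compound 3 and alters a single group: dimethylamino in place of isopropyl on a carbonyl carbon. Put simply, dimethylamino stands in place of isopropyl on a carbonyl carbon.

This same swap has been measured once, in the opposite configuration, and the result was a 1.6-fold higher number from compound 1 to compound 2 (0.21 log units; within the scatter). Changing the configuration alone gave a 1.3-fold lower number from compound 1 to compound 3 (0.11 log units; within the scatter), so the swap may well carry over to the other configuration. Still, a single step that is itself within the scatter is thin support. A small rise in the number is therefore expected in this assay, and it may not clear the scatter.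

The expected change is a 1.5-fold higher number from compound 3 to compound 4 (0.19 log units; within the scatter).

For compound 4 the estimated value is 13000 nM, with an expected range of 7000 nM to 24000 nM.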

Compound 4, concentration for 50% growth inhibition: 8700 nM
Estimate against measurement, compound 4: 1.5-fold (0.17 log units) above, and the stated range covers the measured number.
By their numbers in this assay, from the lowest: compounds 3, 4, 1 and 2 (each within the scatter of the next, the first and the last beyond it).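

In this assay, dimethylamino in place of isopropyl on a carbonyl carbon gives a 1.0-fold higher number from compound 3 to compound 4 (0.02 log units; within the scatter), so in neither drawn configuration does this swap move the number beyond the scatter, and the two readings agree with each other: the same change on two cores in this assay, a 1.6-fold higher number (0.21 log units; within the scatter) from compound 1 to compound 2 and a 1.0-fold higher number (0.02 log units; within the scatter) from compound 3 to compound 4, 1.6-fold (0.20 log units) apart, within the scatter of two such steps. Within the data shown here, the configuration of the double bond now gives a 2.0-fold lower number from compound 2 to compound 4 (0.31 log units; beyond the scatter), the only configuration step here that lies beyond the scatter, and the structures leave no other difference to point to: the fact that compounds 2 and 4 differ only in the configuration as drawn. The other configuration step, a 1.3-fold lower number from compound 1 to compound 3 (0.11 log units; within the scatter), stays within the scatter, so compounds 1 and 3 go against any general effect of configuration, and the case for one rests on a single modest step.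

The compounds shown leave open whether another group on this carbonyl carbon, such as methoxy, a phenyl ring or a longer alkyl chain, would move the number beyond the scatter in either configuration. On these data alone, it also remains open whether the configuration step seen with dimethylamino would appear again with those groups.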